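The source may hold more compounds than are shown below. What is called first, only, known or untested is meant among the compounds shown, and "the series" means these compounds.

Three compounds sharing one core were compared in an ADME assay on HepG2 cells (Homo sapiens) for cytotoxicity, read by MTT assay, with a stated time of 7 days; on this read-out lower numbers stand for stronger inhibition and higher numbers for weaker inhibition. Compound 1 `O=C(c1cccnc1)N1N=C(c2ccc(O)cc2)CC1c1ccccc1Cl` gives 47700 nM. Compound 2 `COc1ccc(C2CC(c3ccc(O)cc3)=NN2C(=O)c2cccnc2)cc1` gives 42400 nM. Compound 3 `Cc1cc(C)c(C2CC(c3ccc(O)cc3)=NN2C(=O)c2cccnc2)c(C)c1` gives 54500 nM. Of the three numbers, that of compound 3 is the largest, yet it is set apart from the others only narrowly: a 1.1-fold higher number from compound 1 to compound 3 (0.06 log units; within the scatter) and a 1.3-fold higher number from compound 2 to compound 3 (0.11 log units; within the scatter), so that no ordering among the three can be claimed.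

Compound 4 `O=C(c1cccnc1)N1N=C(c2ccc(O)cc2)CC1c1ccc([N+](=O)[O-])cc1` has not yet been measured in this assay. It differs from compound 3 in one place: 4-nitrophenyl in place of 2,4,6-trimethylphenyl on a saturated ring carbon.

All three measured steps bear on this change, since each of them also exchanges the aryl group on the saturated ring carbon while the rest of the molecule stays fixed. They were a 1.1-fold lower number from compound 1 to compound 2 (0.05 log units; within the scatter), a 1.1-fold higher number from compound 1 to compound 3 (0.06 log units; within the scatter) and a 1.3-fold higher number from compound 2 to compound 3 (0.11 log units; within the scatter), none of them beyond the scatter. On that basis no step beyond the scatter is expected in this assay from compound 3 to compound 4, and the exchange is expected to amount to a 1.1-fold lower number from compound 3 to compound 4 (0.04 log units; within the scatter). Compound 4 is therefore estimated at 50000 nM, with a range from 30000 nM to 85000 nM.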

Compound 4, half-maximal inhibitory concentration: 18600 nM
For compound 4 the middle estimate is 2.7-fold (0.43 log units) above the measured one; measured number outside the range, below it.
By their numbers in this assay, from the lowest: compound 4; then compounds 2, 1 and 3 (each within the scatter of the next).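

Until now, no aryl group on the saturated ring carbon had moved the number in this assay beyond the scatter, but 4-nitrophenyl does so, with a 2.9-fold lower number from compound 3 to compound 4 (0.47 log units; beyond the scatter) and a 2.6-fold lower number from compound 1 to compound 4 (0.41 log units; beyond the scatter) pointing the same way. The position is therefore not indifferent to the group it carries, and a 2.3-fold lower number from compound 2 to compound 4 (0.36 log units; beyond the scatter) shows that nitro in place of methoxy on an aromatic carbon of the phenyl group is enough to produce a modest step, while 2-chlorophenyl, 4-methoxyphenyl and 2,4,6-trimethylphenyl remain within the scatter of one another. Nothing in the available data accounts for this step.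

On these data alone, whether the lower number is tied to nitro itself remains open, since an amine, a nitrile or a carboxylic acid in its place on the phenyl group could show whether other groups give a similar number. As far as these compounds go, it is also open whether the same exchange would hold if a methoxy group replaced the hydroxyl on the 4-hydroxyphenyl group or if a different acyl group replaced the (pyridin-3-yl)carbonyl group.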